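Swapping Naphthalen-2-yl for 3-Fluoro-5-methoxyphenyl: Cytotoxicity Outlook

This account rests on a few compounds, and the source may have more. Where it says the series, first, only, none or still open, it means among the compounds named here.

Compound 2 `CCOC(=O)CCCCCOc1cccc(CN(C(=O)c2ccc(-c3ccc4ccccc4c3)cc2)C(C)C)c1` was examined in an ADME assay on HepG2 cells (Homo sapiens) for cytotoxicity, read by CellTiter-Glo and resazurin assay, with a stated time of 72 h; a higher number here means that more compound is needed for the effect, a lower number that less compound is needed. In this assay compound 2 reaches only the limit of the assay, > 26000 nM, so no exact number for it is known. Compound 1 `CC(C)N(Cc1cccc(OCCCCCC(=O)O)c1)C(=O)c1ccc(-c2cccc(O)c2)cc1` sits at the same kind of limit, since in this assay compound 1 gives > 26000 nM. Both measured values therefore share (the limit of > 26000 nM in this assay, at which 2 of the 2 values shown sit). Compound 3 `CCOC(=O)CCCCCOc1cccc(CN(C(=O)c2ccc(-c3cc(F)cc(OC)c3)cc2)C(C)C)c1` has not yet been measured; it differs from compound 2 by 3-fluoro-5-methoxyphenyl in place of naphthalen-2-yl on an aromatic carbon. Within the data shown here, no step between two measured compounds is known here, so the size of the change can only be expected, not read off. With both known values sitting at a limit, the expected step that the limit leaves unreadable from compound 2 to compound 3 is none beyond the scatter, and compound 3 is expected to end at a limit as well. Compound 3 is estimated at 30000 nM, with a range from 12000 nM to 80000 nM.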

Compound 3, half-maximal effective concentration: > 26000 nM
Compound 3 ended at the assay's limit (the forecaster's own chance of this, stated with the estimate: 80%); the middle value lies beyond the limit too.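

In this assay, no step can be read from compound 2 to compound 3, since both sit at a limit: the limit of > 26000 nM in this assay, at which 3 of the 3 values shown sit. The compounds shown leave open what concentration any of them needs for the effect, and whether swapping naphthalen-2-yl for 3-fluoro-5-methoxyphenyl changes it.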